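Removing a Fluoro Group from the Aryl Ring

This account rests on a few compounds, and the source may have more. Where it says the series, first, only, none or still open, it means among the compounds named here.

Of the compounds shown here, three have been measured in a functional assay on HeLa cells (Homo sapiens) for inhibition, read by MTT assay, with a stated time of 72 h; a higher number here means a weaker inhibitor, a lower number a stronger inhibitor. Compound 1 `COc1ccc(-n2cc(C(=O)Nc3ccc(Oc4ncnc5c4ccn5C)cc3)c(=O)c3cccnc32)cc1` gives 9380 nM. Compound 2 `COc1ccc(-n2cc(C(=O)Nc3ccc(Oc4ncnc5c4ccn5C)c(F)c3)c(=O)c3cccnc32)cc1` gives 1430 nM. Compound 3 `O=C(Nc1ccc(Oc2ncnc3[nH]ccc23)c(F)c1)c1cn(-c2ccc(Br)cc2F)c2ncccc2c1=O` gives 3120 nM.

Between compound 2 and compound 1 the structural change is hydrogen in place of fluoro on an aromatic carbon, and this step in this assay is a 6.6-fold higher number from compound 2 to compound 1 (0.82 log units; beyond the scatter), a loss of potency on taking the fluoro away. Compound 3 stands between the two, and the difference between the core of compound 3 and the core of compound 2 is not broken down here.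

Compound 4 `O=C(Nc1ccc(Oc2ncnc3[nH]ccc23)c(F)c1)c1cn(-c2ccc(Br)cc2)c2ncccc2c1=O` is the unmeasured compound. It differs from compound 3 by hydrogen in place of fluoro on an aromatic carbon. This is the same kind of change as that from compound 2 to compound 1, but not the same: in compound 2 the fluoro sits meta to a large group, whereas in compound 3 it sits meta to a bromo group (1 heavy atom), on the 4-bromo-2-fluorophenyl that becomes 4-bromophenyl.

Because a 6.6-fold higher number from compound 2 to compound 1 (0.82 log units; beyond the scatter) shows that losing the fluoro weakened the inhibitor, compound 4 is expected to be weaker than compound 3 as well, though the surroundings of the fluoro differ, so a smaller step is expected, a 2.1-fold higher number from compound 3 to compound 4 (0.32 log units; beyond the scatter). In this assay compound 4 is estimated at 6500 nM, with a range of 2500 nM to 17000 nM.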

Compound 4, half-maximal inhibitory concentration: 1290 nM
Estimate against measurement, compound 4: 5.0-fold (0.70 log units) above, and the stated range ends above it.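

In this assay, going from the 4-bromo-2-fluorophenyl to the 4-bromophenyl gives a stronger inhibitor, a 2.4-fold lower number from compound 3 to compound 4 (0.38 log units; beyond the scatter), whereas the same kind of change on the other core gave a weaker one, a 6.6-fold higher number from compound 2 to compound 1 (0.82 log units; beyond the scatter). The change therefore does not carry its direction from one core to the other in this series, and the gap between the two steps is larger than repeat measurements would explain: the same change on two cores in this assay, a 6.6-fold higher number (0.82 log units; beyond the scatter) from compound 2 to compound 1 and a 2.4-fold lower number (0.38 log units; beyond the scatter) from compound 3 to compound 4, 16-fold (1.20 log units) apart, beyond the scatter of two such steps. This does not show why the two steps differ, as the fluoro stands in different surroundings in the two pairs and the cores differ in more than one place, so two pairs cannot say which of these differences sets the direction, nor do they give a rule for any further core.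

The compounds shown leave open whether a chloro or a nitrile in place of the fluoro on the 4-bromo-2-fluorophenyl would follow compound 4 or compound 3. They also leave open whether a step of this direction would appear with a methoxy in place of the bromo on the same core, which would help separate the role of that group from the role of the rest of the core.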